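Adding a 2-methoxyethoxy group to a short-lived compound

A few compounds are considered here, and "the series" means these few. Any claim that something is new, unique, unknown or untested is made for them only; others in the source may bear on it.

Compound 1 `CC#C[C@@H](Cc1nnn[nH]1)c1ccc(OCc2ccc3sc(F)c(-c4ccc(OCCOC)cc4C)c3c2)cc1`: 1.95 h
Compound 2 `CC#C[C@@H](Cc1nnn[nH]1)c1ccc(OCc2ccc3sc(C)c(-c4ccccc4C)c3c2)cc1`: 0.0667 h

Of the compounds shown here, two have been measured in an ADME assay on microsomes from liver (Homo sapiens) for metabolic stability; on this read-out higher numbers stand for a longer-lived compound and lower numbers for a shorter-lived compound. Compound 2 stands lowest of the two numbers, and the nearest number, that of compound 1, is far higher, well beyond the scatter; these two compounds differ in more than one place, so their values show only that they sit far apart. Compound 3 `CC#C[C@@H](Cc1nnn[nH]1)c1ccc(OCc2ccc3sc(C)c(-c4ccc(OCCOC)cc4C)c3c2)cc1` is not yet measured. It differs from compound 2 in one place: 2-methoxyethoxy in place of hydrogen on an aromatic carbon. Compound 1 also carries this 2-methoxyethoxy group and gives 1.95 h in this assay, but it differs from compound 3 elsewhere as well, so it gives no direct guide. Compound 3 is expected to show an upward step a 3.0-fold higher number from compound 2 to compound 3 (0.48 log units; beyond the scatter) of modest size, perhaps not beyond the scatter. Compound 3 is estimated at 0.2 h, within a range of 0.06 h to 0.7 h.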

Compound 3, half-life: 1.48 h
Beside the measured number, compound 3's estimate is 7.4-fold (0.87 log units) below it; measured number outside the range, above it.
By their numbers in this assay, from the lowest: compound 2; then compounds 3 and 1 (each within the scatter of the next).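

In this assay, the change from 2-methylphenyl to 4-(2-methoxyethoxy)-2-methylphenyl gives a 22-fold higher number from compound 2 to compound 3 (1.35 log units; beyond the scatter) as a large step, so this single change at this position is now tied to a large rise in half-life, which the earlier pair, differing in more than one place, could not show. With the 2-methoxyethoxy group present, methyl in place of fluoro on an aromatic carbon gives a 1.3-fold lower number from compound 1 to compound 3 (0.12 log units; within the scatter) and does not separate the two compounds. Nothing shown here bears on why the step from the added group is so large.

On these data alone, it remains open whether a methoxy group, a longer ether chain or an amine at the same place would give a similar half-life. Also open, as far as these compounds go, is whether the 2-methoxyethoxy group would give a step of this size with fluoro in place of methyl on the shared core.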